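This account rests on a few compounds, and the source may have more. Where it says the series, first, only, none or still open, it means among the compounds named here.

Compound 1 `Cc1cc(O)c(C2=NN(c3ccc(S(N)(=O)=O)cc3)C(c3ccccc3O)C2)cc1Cl` and compound 2 `COc1ccc(C2CC(c3cc(Cl)c(C)cc3O)=NN2c2ccc(S(N)(=O)=O)cc2)cc1OC` share one core and differ only in the group on a saturated ring carbon. In a functional assay on MDA-MB-231 cells (Homo sapiens) for antiproliferative activity, with a stated time of 48 h (on this read-out higher numbers stand for lower toxicity in this test and lower numbers for higher toxicity in this test), compound 1 gives 29500 nM, the lesser of the two numbers shown, and compound 2 gives 40400 nM; the step of a 1.4-fold higher number from compound 1 to compound 2 (0.14 log units; within the scatter) lies within the scatter, so the two values cannot be told apart. Compound 3 `COc1ccc(C2CC(c3cc(Cl)c(C)cc3O)=NN2c2ccc(S(N)(=O)=O)cc2)c(OC)c1OC` has not yet been measured. It differs from compound 1 in that (2,3,4-trimethoxyphenyl in place of 2-hydroxyphenyl on a saturated ring carbon). For the measured compounds named here, the only measured step that bears on this, from compound 1 to compound 2, put 3,4-dimethoxyphenyl in the same place and moved the number by a 1.4-fold higher number from compound 1 to compound 2 (0.14 log units; within the scatter). Going further to 2,3,4-trimethoxyphenyl therefore gives no ground to expect a step beyond the scatter, and the expected step for compound 3 is a 1.2-fold higher number from compound 1 to compound 3 (0.07 log units; within the scatter). The estimate for compound 3 in this assay is 35000 nM, with a range from 14000 nM to 90000 nM.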

Compound 3, concentration lethal to 50% of the cells: 16300 nM
For compound 3 the middle estimate is 2.1-fold (0.33 log units) above the measured one; the range from low to high includes it.
By their numbers in this assay, from the lowest: compounds 3, 1 and 2 (each within the scatter of the next, the first and the last beyond it).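

In this assay, the group on the saturated ring carbon can move the number beyond the scatter: methoxy in place of hydrogen on an aromatic carbon, which turns 3,4-dimethoxyphenyl into 2,3,4-trimethoxyphenyl, gives a 2.5-fold lower number from compound 2 to compound 3 (0.39 log units; beyond the scatter), a modest step towards higher toxicity in this test. For the compounds shown here, replacing the 2-hydroxyphenyl group with 2,3,4-trimethoxyphenyl gives a 1.8-fold lower number from compound 1 to compound 3 (0.26 log units; within the scatter), so those two compounds cannot be told apart, and the single added methoxy is the only change here with a readable effect. Nothing measured here explains that step.

The compounds shown leave open how a phenyl carrying only one methoxy, or one carrying an amine or a carboxylic acid, would read on the same saturated ring carbon. They also leave open whether the step seen with the added methoxy would hold in other cell lines.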